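A few compounds are considered here, and "the series" means these few. Any claim that something is new, unique, unknown or untested is made for them only; others in the source may bear on it.

In an ADME assay on HEK293 cells (Homo sapiens) for inhibition, read by MTT assay, with stated times of 18 h and 4 h (on this read-out lower numbers stand for stronger inhibition and higher numbers for weaker inhibition), compound 1 (`CCCCCCCCOP(=O)(O)OCCSC(=S)N1CCN(C)CC1`) gives 86000 nM as a measured number. Compound 2 (`CCCCCCOP(=O)(O)OCCSC(=S)N1CCN(C)CC1`) gives no number, only the limit > 100000 nM in this assay. Its standing is thus (the limit of > 100000 nM in this assay, at which 1 of the 2 values shown sits) a bound and not a position. Compound 3 (`CCCOP(=O)(O)OCCSC(=S)N1CCN(C)CC1`) shortens the chain further, with hydrogen in place of propyl on a saturated chain carbon, three bonds along the chain from an oxygen on an unsaturated carbon as the difference, hydrogen in place of propyl on a saturated chain carbon, three bonds along the chain from an oxygen on an unsaturated carbon. For the measured compounds named here, the one measured step that bears on this is an at least 1.1-fold higher number from compound 1 to compound 2 (0.06 log units; that floor lies within the scatter) and it stays within the scatter, ending at a limit. Going by the values given here, with only that step to go on, no change beyond the scatter is expected in this assay and another limit reading is likely. The estimated step is a step that the limit leaves unreadable from compound 2 to compound 3 and it is expected to point, if anywhere, to a higher number. For compound 3 the expected value is 150000 nM with an estimated range from 80000 nM to 300000 nM overall.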

Compound 3, half-maximal inhibitory concentration: 39600 nM
For compound 3 the middle estimate is 3.8-fold (0.58 log units) above the measured one; measured number outside the range, below it.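

In this assay, the change at this place, on a saturated chain carbon, three bonds along the chain from an oxygen on an unsaturated carbon, moves the read-out beyond the scatter: there is an at least 2.5-fold lower number from compound 2 to compound 3 (0.40 log units; beyond the scatter), and there is also a 2.2-fold lower number from compound 1 to compound 3 (0.34 log units; beyond the scatter). Compound 3, with the shortest chain of the three, therefore has the lowest number, and the read-out does not simply weaken as the chain shortens, which the earlier pair could not show. The reading for compound 2 is a limit and not a number, so the step that starts from it gives only a floor: the limit of > 100000 nM in this assay, at which 1 of the 3 values shown sits.

The compounds shown leave open whether a still shorter chain, such as ethyl or methyl, would lower the number further. They also leave open what a longer chain, or an amine or carboxylic acid at the chain end, would do at this place.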